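The source may hold more compounds than are shown below. What is called first, only, known or untested is meant among the compounds shown, and "the series" means these compounds.

Working notes on the series. The shared core carries a benzylthio-linked dithiocarbamate; the variation sits on the ring amine. Compound 1, `Nc1ccccc1NC(=O)c1ccc(CSC(=S)N2CCN(C(c3ccccc3)c3ccccc3)CC2)cc1`, gives 9.9% in a functional assay on MGC-803 cells (Homo sapiens) for antiproliferative activity, read by CCK-8 assay, with a stated time of 72 h, tested at 8 uM; a higher number here means a stronger effect of the compound at the concentration tested, a lower number a weaker effect. Compound 3, `Nc1ccccc1NC(=O)c1ccc(CSC(=S)N2CCc3cc([N+](=O)[O-])ccc32)cc1`, gives 33.2% in this assay. Compound 2, `Nc1ccccc1NC(=O)c1ccc(CSC(=S)N2CCN(c3cccnc3)CC2)cc1`, gives 76.9% in this assay and stands highest of the three numbers, beyond the scatter against both compound 3 and compound 1.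

Compound 4, `Nc1ccccc1NC(=O)c1ccc(CSC(=S)N2CCN(c3cnccn3)CC2)cc1`, is not yet measured. It differs from compound 2 in one place: pyrazin-2-yl in place of pyridin-3-yl on an amine nitrogen in a ring. With only these three measurements the step from compound 2 to compound 4 is expected to be small, and if anything a slight decrease, perhaps no more than the scatter, as a number 10.9 percentage points lower from compound 2 to compound 4 (beyond the scatter). Compound 4 is therefore expected to give about 66% in this assay, in a range from 42% to 85%.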

Compound 4, a percentage reported as inhibition, at one concentration (the size of the read-out at that concentration, not a potency): 80.5%
Compound 4: the middle estimate sits 14.5 percentage points below what was measured; the measured number falls inside the stated range.
By their numbers in this assay, from the lowest: compound 1; then compound 3; then compounds 2 and 4 (each within the scatter of the next).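

In this assay, for the compounds shown here, the step with pyrazin-2-yl in place of pyridin-3-yl is a number 3.6 percentage points higher from compound 2 to compound 4 (within the scatter) and gives the first one-place comparison. On this amine nitrogen in a ring, an aromatic ring with 2 hetero atoms and one with 1 hetero atom therefore cannot be told apart in this read-out. Nothing measured here explains this match. Still open, from the compounds shown here alone, is whether a plain phenyl ring, with no ring nitrogen, on the same amine nitrogen would keep the read-out at this level.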